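Thiophene for Fluorophenyl on the Thiosemicarbazone Hydrazone

A few compounds are considered here, and "the series" means these few. Any claim that something is new, unique, unknown or untested is made for them only; others in the source may bear on it.

The series shares a thiosemicarbazone core joined to an aromatic hydrazone. Compound 1 `CC1=CC[C@H](C(C)(C)NC(=S)N/N=C/c2ccccc2)CC1` gives 5700 nM in a functional assay on PC-3 cells (Homo sapiens) for inhibition, read by sulforhodamine B assay, with a stated time of 48 h; a higher number here means a weaker inhibitor of growth, a lower number a stronger inhibitor of growth. Compound 2 `CC1=CC[C@H](C(C)(C)NC(=S)N/N=C/c2ccc(F)cc2)CC1` was measured only to a limit of the assay, and in this assay compound 2 gives < 900 nM. Within the numbers shown, compound 2 therefore stands at the stronger end, as described by the limit of < 900 nM in this assay, at which 1 of the 2 values shown sits, but how far beyond that limit it reaches is not known. Among the compounds with values here, the one measured step, an at least 6.3-fold lower number from compound 1 to compound 2 (0.80 log units; beyond the scatter), runs from an unsubstituted phenyl to its fluoro analogue.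

Compound 3 `CC1=CC[C@H](C(C)(C)NC(=S)N/N=C/c2cccs2)CC1` differs from compound 2 by thiophen-2-yl in place of 4-fluorophenyl on a carbon with a double bond to nitrogen. Within the data shown here, no measured pair exchanges one aromatic ring for another, so the fluoro step of compound 1 to compound 2 bears only loosely on this change; it shows that the aromatic end of the molecule can move the number at least modestly. With compound 2 known only as a limit, compound 3 is expected to stay near the same region, with an estimated step of an at least 1.6-fold higher number from compound 2 to compound 3 (0.22 log units; that floor lies within the scatter). Compound 3 is therefore estimated at 1500 nM in this assay, with a range from 500 nM to 5000 nM.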

Compound 3, concentration for total growth inhibition: 62800 nM
Beside the measured number, compound 3's estimate is 42-fold (1.62 log units) below it; measured number above the stated range.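

In this assay, the carbon with a double bond to nitrogen proves sensitive to the identity of the aromatic ring itself, not only to a substituent on that ring. Putting thiophen-2-yl in place of phenyl gives an 11-fold higher number from compound 1 to compound 3 (1.04 log units; beyond the scatter), a move in the opposite direction to the fluoro step and one that makes compound 3 the weakest of the three compounds shown. Putting thiophen-2-yl in place of 4-fluorophenyl gives an at least 69-fold higher number from compound 2 to compound 3 (1.84 log units; beyond the scatter), a size that stands only as a floor because compound 2 is known only as a limit of the assay: the limit of < 900 nM in this assay, at which 1 of the 3 values shown sits.

The compounds shown do not separate the sulfur of thiophen-2-yl from the change from a six-membered to a five-membered ring, and they give no reason for the large loss in growth inhibition. On these data alone, how furan-2-yl, with oxygen in the five-membered ring, or pyridin-2-yl, with nitrogen in a six-membered ring, would read in this assay remains open, as does how far compound 2 lies beyond its limit.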